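Inverting two ring stereocentres in a neprilysin inhibitor

The source may report more compounds than this note shows. Statements on the series, on what has been measured and on what is new or still open speak of the compounds shown alone.

Three compounds measured in an assay on isolated protein for inhibition of Neprilysin (Oryctolagus cuniculus) (on this read-out higher numbers stand for weaker inhibition and lower numbers for stronger inhibition), share a core carrying a free thiol and a carboxylic acid. Compound 1 `O=C(NCC(=O)N1[C@@H](c2ccccc2O)CC[C@H]1C(=O)O)[C@@H](S)Cc1ccccc1` gives 1 nM. Compound 2 `O=C(NCC(=O)N1[C@@H](c2cccc(O)c2)CC[C@H]1C(=O)O)[C@@H](S)Cc1ccccc1` gives 2.4 nM, and compound 3 `Cc1ccccc1[C@H]1CC[C@@H](C(=O)O)N1C(=O)CNC(=O)[C@@H](S)Cc1ccccc1` gives 5.3 nM. Among these three numbers compound 3 stands highest: the step of a 2.2-fold higher number from compound 2 to compound 3 (0.34 log units; beyond the scatter) and the step of a 5.3-fold higher number from compound 1 to compound 3 (0.72 log units; beyond the scatter) are both modest, and each exchanges one group on the aryl ring attached to the saturated ring.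

Compound 4 `Cc1ccccc1[C@@H]1CC[C@H](C(=O)O)N1C(=O)CNC(=O)[C@@H](S)Cc1ccccc1` is built from compound 3 by a different kind of change: the two compounds have the same atoms and bonds and differ only in configuration as drawn: 2 of 3 stereo elements differ; a stereocentre at a saturated ring carbon is drawn R in compound 3 and S in compound 4; a stereocentre at a saturated ring carbon is drawn S in compound 3 and R in compound 4. For the measured compounds named here, no measured step alters configuration, so none of the three steps speaks directly to this change; all of them concern groups, not spatial arrangement. With nothing to anchor it, the expectation rests on the general observation that flipping two stereocentres on a ring that holds the acid usually costs potency, and the expected step of a 38-fold higher number from compound 3 to compound 4 (1.58 log units; beyond the scatter) is therefore sizeable and towards weaker inhibition, though with wide uncertainty. Compound 4 is estimated at 200 nM, within a range from 20 nM to 2000 nM in this assay.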

Compound 4, half-maximal inhibitory concentration: 8.5 nM
Compound 4: the middle estimate sits 24-fold (1.37 log units) above what was measured, and the stated range ends above it.
By their numbers in this assay, from the lowest: compound 1; then compound 2; then compounds 3 and 4 (each within the scatter of the next).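

In this assay, for the compounds shown here, the step of a 1.6-fold higher number from compound 3 to compound 4 (0.21 log units; within the scatter) gives the first view of what configuration at these two saturated ring carbons does, as all the earlier steps exchanged groups on the aryl ring. With the 2-methylphenyl group kept, compounds 3 and 4 cannot be told apart on this read-out, so for this pair, inverting both ring stereocentres together has no effect that can be distinguished from the scatter. The comparison isolates spatial arrangement alone: the fact that compounds 3 and 4 differ only in the configuration as drawn.

The compounds shown leave open what inverting just one of these ring carbons would do, and whether the same inversion would be as well tolerated with the hydroxy groups of compound 1 and compound 2. Nor do they show how it would play out with an amine on the aryl ring.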